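The source may report more compounds than this note shows. Statements on the series, on what has been measured and on what is new or still open speak of the compounds shown alone.

In an assay on HEK-293T cells for displacement of a labelled ligand from corticotropin-releasing factor receptor 2 (Homo sapiens), read by scintillation counting, with a stated time of 2 h, tested at 1 uM (a lower number here means less inhibition, a higher number more inhibition at the concentration tested (going by the name of the read-out)), compound 1 `CCCCN(CC)c1cc(C)nc2c1NC(=O)CN2c1ccc(C)cc1C` gives 6.8%. Compound 2 `CCCCN(CC)c1cc(C)nc2c1NC(=O)CN2c1ccc(C(C)C)cc1Br` in this assay gives 0.7%. Compound 2 stands alongside compound 1: the gap between the two numbers lies within the scatter, so the two cannot be told apart, and both show little inhibition at the concentration tested. Compound 3 `CCCCN(CC)c1cc(C)nc2c1NC(=O)CN2c1ccc(C(C)(C)C)cc1Br` differs from compound 2 by methyl in place of hydrogen on a saturated chain carbon bound to an aromatic carbon and two saturated chain carbons. Within the data shown here, no measured pair isolates such a change. The expected step is a number 2.3 percentage points higher from compound 2 to compound 3 (within the scatter), none beyond the scatter. Compound 3 is therefore estimated at 3%, with a range from -8% to 15%.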

Compound 3, a percentage reported as inhibition, at one concentration (the size of the read-out at that concentration, not a potency): -3.8%
Estimate against measurement, compound 3: 6.8 percentage points above; the range from low to high includes it.
By their numbers in this assay, from the lowest: compounds 3, 2 and 1 (each within the scatter of the next, the first and the last beyond it).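

The change from isopropyl to tert-butyl gives a number 4.5 percentage points lower from compound 2 to compound 3 (within the scatter) in this assay and so cannot be told apart from no change at all. At this saturated chain carbon, then, an added methyl brings no inhibition into view at the concentration tested, and compound 2 and compound 3 both remain at little inhibition. Nothing measured here offers an explanation for this result. On these data alone, it remains open whether any group in this place can produce clear inhibition, for instance a hydroxyl or an amine in place of the added methyl.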